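This account rests on a few compounds, and the source may have more. Where it says the series, first, only, none or still open, it means among the compounds named here.

Three compounds share one core and differ only on the amine nitrogen in a ring. Compound 1 `COC(=O)C[C@H](NC(=O)OC(C)(C)C)C(=O)N(Cc1ccc(F)cc1)C1(C(=O)NCc2ccccc2)CCN(C)CC1` gives 17000 nM in an ADME assay on MDCK cells (Canis lupus familiaris) for cytotoxicity, read by microscopy, with a stated time of 72 h; on this read-out higher numbers stand for lower toxicity in this test and lower numbers for higher toxicity in this test. Compound 2 `COC(=O)C[C@H](NC(=O)OC(C)(C)C)C(=O)N(Cc1ccc(F)cc1)C1(C(=O)NCc2ccccc2)CCN(C2CCCCC2)CC1` gives 73000 nM in this assay, and compound 3 `COC(=O)C[C@H](NC(=O)OC(C)(C)C)C(=O)N(Cc1ccc(F)cc1)C1(C(=O)NCc2ccccc2)CCN(Cc2cccc(F)c2)CC1` gives 84000 nM in this assay. Compound 3 thus holds the highest of the three numbers, though the step of a 1.2-fold higher number from compound 2 to compound 3 (0.06 log units; within the scatter) lies within the scatter, while a 4.9-fold higher number from compound 1 to compound 3 (0.69 log units; beyond the scatter) and a 4.3-fold higher number from compound 1 to compound 2 (0.63 log units; beyond the scatter) lie beyond it. Compound 4 `COC(=O)C[C@H](NC(=O)OC(C)(C)C)C(=O)N(Cc1ccc(F)cc1)C1(C(=O)NCc2ccccc2)CCN(Cc2cc(F)cc(F)c2)CC1` differs from compound 3 by fluoro in place of hydrogen on an aromatic carbon. Within the data shown here, no measured step adds a fluoro to the 3-fluorobenzyl group; the steps that bear on this part of the molecule exchange the whole group on the amine nitrogen, and the one nearest in kind, from cyclohexyl to 3-fluorobenzyl, stayed within the scatter. Compound 4 is therefore expected to show a 1.1-fold higher number from compound 3 to compound 4 (0.03 log units; within the scatter), a change not beyond the scatter. Compound 4 is estimated at 90000 nM in this assay, with a range from 40000 nM to 200000 nM.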

Compound 4, minimum cytotoxic concentration: 100000 nM
Compound 4: middle estimate off by 1.1-fold (0.05 log units), on the low side; the measured number falls inside the stated range.
By their numbers in this assay, from the lowest: compound 1; then compounds 2, 3 and 4 (each within the scatter of the next).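

Adding a fluoro to the 3-fluorobenzyl group changes only the aromatic ring, not the whole group on the amine nitrogen, and in this assay it gives a 1.2-fold higher number from compound 3 to compound 4 (0.08 log units; within the scatter). The 3,5-difluorobenzyl group also stays close to cyclohexyl, with a 1.4-fold higher number from compound 2 to compound 4 (0.14 log units; within the scatter), but stands apart from methyl, with a 5.9-fold higher number from compound 1 to compound 4 (0.77 log units; beyond the scatter), so among the four groups shown only methyl is separated from the others. Nothing available explains these readings.

The compounds shown leave open how a plain benzyl group with no fluoro on its ring would read, so the effect of the first fluoro cannot be judged. They also leave open whether a methoxy group or a nitrile on that ring, or an acetyl group on the amine nitrogen, would stay within the scatter of these compounds.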